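A few compounds are considered here, and "the series" means these few. Any claim that something is new, unique, unknown or untested is made for them only; others in the source may bear on it.

Measured so far in a functional assay on MCF7 cells (Homo sapiens) for antiproliferative activity, with a stated time of 5 days; a higher number here means a weaker inhibitor, a lower number a stronger inhibitor:
compound 1 `CCCCc1ccc2[nH]c(-c3ccc(OC)cc3)c(/C=N/NC(=O)c3ccc(Cl)cc3)c2c1`: 220 nM
compound 2 `CCCCc1ccc2[nH]c(-c3ccc(C(F)(F)F)cc3)c(/C=N/NC(=O)c3ccc(Cl)cc3)c2c1`: 1060 nM
compound 3 `CCCCc1ccc2[nH]c(-c3ccc(C(F)(F)F)cc3)c(/C=N/NC(=O)c3ccc(OC)cc3)c2c1`: 618 nM

Compound 1 holds the lowest number of the three, and the values of the other two lie beyond the scatter from it. The next compound is compound 4 `CCCCc1ccc2[nH]c(-c3ccc(OC)cc3)c(/C=N/NC(=O)c3ccccc3OC)c2c1`, with the change 2-methoxyphenyl in place of 4-chlorophenyl on a carbonyl carbon.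

The closest measured step is a 1.7-fold lower number from compound 2 to compound 3 (0.23 log units; within the scatter), methoxy in place of chloro on an aromatic carbon, and it stays within the scatter. Going by the values given here, it is only a partial guide, as no measured compound carries the 2-methoxyphenyl group. The other step, a 4.8-fold higher number from compound 1 to compound 2 (0.68 log units; beyond the scatter), is a change elsewhere in the molecule, and compound 4 does not make it. It shows only that the series can move by a modest amount.

With compound 1 the lowest so far at 220 nM, a modest rise is expected in this assay rather than a fall. The expected step is a 1.9-fold higher number from compound 1 to compound 4 (0.28 log units; within the scatter). For compound 4 the estimate is 420 nM, with an expected range of 150 nM to 1200 nM.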

Compound 4, half-maximal inhibitory concentration: 71 nM
Estimate against measurement, compound 4: 5.9-fold (0.77 log units) above; the measured number lies below the stated range.
By their numbers in this assay, from the lowest: compound 4; then compound 1; then compounds 3 and 2 (each within the scatter of the next).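

The aryl group on the carbonyl carbon can move the number in this assay beyond the scatter: 2-methoxyphenyl in place of 4-chlorophenyl gives the step (a 3.1-fold lower number from compound 1 to compound 4 (0.49 log units; beyond the scatter)). The earlier change on this aryl group, methoxy in place of chloro (a 1.7-fold lower number from compound 2 to compound 3 (0.23 log units; within the scatter)), stayed within the scatter and left this part of the molecule without a readable effect. No measured property of these compounds bears on the cause of the new step.

The compounds shown do not separate the contribution of the methoxy group from that of its location on the ring, nor show whether the step carries over to a partner bearing 4-trifluoromethylphenyl on the core. On these data alone, how an ethoxy group or a dimethylamino group would behave on this aryl ring also remains open.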